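The source may report more compounds than this note shows. Statements on the series, on what has been measured and on what is new or still open speak of the compounds shown alone.

In a functional assay on MGC-803 cells (Homo sapiens) for antiproliferative activity, read by CCK-8 assay, with a stated time of 72 h (on this read-out lower numbers stand for stronger inhibition and higher numbers for weaker inhibition), compound 1 (`Nc1ccccc1NC(=O)c1ccc(COc2ccc(Br)cc2)cc1`) gives > 32000 nM as its reading, and that is a limit of the assay, not a number. Among the compounds with values here, compound 2 (`Cc1ccc(OCc2ccc(C(=O)Nc3ccccc3N)cc2)cc1`) gives 6530 nM and holds the only true number so far. Methyl in place of bromo on an aromatic carbon brought an at least 4.9-fold lower number from compound 1 to compound 2 (0.69 log units; beyond the scatter) as the one measured step, and it lies beyond the scatter. Compound 3 (`COc1ccc(OCc2ccc(C(=O)Nc3ccccc3N)cc2)cc1`) alters that same carbon again, with methoxy in place of methyl on an aromatic carbon as the counted difference: methoxy in place of methyl. A single step that starts from a limit gives no clear direction for this new change. With compound 2 at 6530 nM as the sole anchor, no shift beyond the scatter is expected in this assay for this change. The expected step is a 1.1-fold lower number from compound 2 to compound 3 (0.04 log units; within the scatter) and remains only an estimate. Compound 3 is estimated at 6000 nM with an expected range from 2000 nM to 18000 nM in this reading.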

Compound 3, half-maximal inhibitory concentration: 3480 nM
Estimate against measurement, compound 3: 1.7-fold (0.24 log units) above; the range from low to high includes it.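

In this assay, within the data shown here, the change from 4-methylphenyl to 4-methoxyphenyl gives a 1.9-fold lower number from compound 2 to compound 3 (0.27 log units; within the scatter), the first step here between two true numbers, and it shows that this carbon takes methoxy as well as methyl with no shift that can be told from repeat measurements. Set against the bromo compound, methoxy gives an at least 9.1-fold lower number from compound 1 to compound 3 (0.96 log units; beyond the scatter), which lies beyond the scatter, as the methyl step does. For compound 1 the reading is a limit and not a number, so this step gives only a lower bound on the difference: the limit of > 32000 nM in this assay, at which 1 of the 3 values shown sits.

Going by these compounds, it stays open whether an amine, a carboxylic acid or a longer chain such as ethoxy on this carbon would hold the reading near those of compound 2 and compound 3. On these data alone, it also stays open whether methoxy would read the same on another carbon of this ring.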